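The source may report more compounds than this note shows. Statements on the series, on what has been measured and on what is new or still open speak of the compounds shown alone.

Compound 2, `COc1ccc(-c2cn3cc(C4=CCN(S(=O)(=O)c5ccccc5)CC4)ccc3n2)cc1OC`, was tested in an ADME assay on HEK293 cells (Homo sapiens) for cytotoxicity, read by MTT assay, with a stated time of 48 h (a lower number here means a stronger inhibitor, a higher number a weaker inhibitor), and gives 65600 nM. Compound 1, `COc1ccc(-c2cn3cc(C4=CCN(C(=O)c5cccc(C(F)(F)F)c5)CC4)ccc3n2)cc1OC`, gives 68400 nM. Compound 2 holds the lowest of the two numbers, yet a 1.0-fold lower number from compound 1 to compound 2 (0.02 log units; within the scatter), so the two compounds cannot be told apart on this measure.

Compound 3, `COc1ccc(-c2cn3cc(C4=CCN(S(=O)(=O)CCc5ccccc5)CC4)ccc3n2)cc1OC`, differs from compound 2 in one place: phenethyl in place of phenyl on a sulfonyl sulfur.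

Among the measured compounds shown here, the only measured step, from compound 1 to compound 2, also changed the group that hangs from the amine nitrogen in the ring, and it stayed within the scatter. On that basis the change to the phenethyl group is expected to leave this assay much where it is, with a 1.0-fold lower number from compound 2 to compound 3 (0.00 log units; within the scatter) expected. Compound 3 is therefore estimated at 65000 nM, with a range from 30000 nM to 140000 nM.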

Compound 3, half-maximal inhibitory concentration: 70300 nM
For compound 3 the middle estimate is 1.1-fold (0.03 log units) below the measured one; the measured number falls inside the stated range.
By their numbers in this assay, from the lowest: compounds 2, 1 and 3 (each within the scatter of the next).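

In this assay, among the compounds shown here, phenethyl in place of phenyl on the sulfonyl sulfur gives a 1.1-fold higher number from compound 2 to compound 3 (0.03 log units; within the scatter), the first reading of a change made on the sulfur itself rather than on the ring nitrogen. The wider swap of phenethylsulfonyl in place of (3-(trifluoromethyl)phenyl)carbonyl on that nitrogen gives a 1.0-fold higher number from compound 1 to compound 3 (0.01 log units; within the scatter), so across these three compounds neither the longer phenethyl group nor the sulfonyl or carbonyl link separates the numbers. Nothing measured here offers a reason for this flat result.

Still open, from the compounds shown here alone, is whether an amine, a carboxylic acid or a chain longer than phenethyl on the sulfonyl sulfur would move the number beyond the scatter. Also open, going by these compounds, is whether a change to the shared core would do so.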